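Butyl in Place of Nitro: What to Expect for Compound 4

A few compounds are considered here, and "the series" means these few. Any claim that something is new, unique, unknown or untested is made for them only; others in the source may bear on it.

Of the compounds shown here, three have been measured in an assay for inhibition of histone acetyltransferase KAT2B (Homo sapiens), read by fluorescence; on this read-out higher numbers stand for weaker inhibition and lower numbers for stronger inhibition. Compound 1 `Cc1cnc2sn(-c3ccc([N+](=O)[O-])cc3)c(=O)c2c1` gives 15300 nM. Compound 2 `O=c1ccsn1-c1ccc(Cl)c([N+](=O)[O-])c1` gives 4800 nM. Compound 3 `O=c1c2cccnc2sn1-c1ccc([N+](=O)[O-])cc1` gives 4100 nM, the lowest of the three numbers; its gap to compound 2 lies within the scatter, while its gap to compound 1 lies beyond it. Among the measured compounds shown here, the single step between two compounds that differ in one place is a 3.7-fold lower number from compound 1 to compound 3 (0.57 log units; beyond the scatter), hydrogen in place of methyl on an aromatic carbon.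

Compound 4 `CCCCc1ccc(-n2sc3ncccc3c2=O)cc1` has not yet been measured. It differs from compound 3 in this way: butyl in place of nitro on an aromatic carbon. The change sits on an aromatic carbon of a six-membered aromatic ring of carbon only, para to a large group. For the measured compounds named here, no measured step bears on it: the one known step concerns methyl against hydrogen elsewhere in the shared core, and all three measured compounds carry the nitro group, so nothing shows what its exchange for butyl does. The expected step in this assay is therefore uncertain in direction and size, and a broad range is needed. Compound 4 is estimated at 8000 nM, between 1500 nM and 40000 nM, which means an expected step of a 2.0-fold higher number from compound 3 to compound 4 (0.29 log units; within the scatter).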

Compound 4, half-maximal inhibitory concentration: 15900 nM
Estimate against measurement, compound 4: 2.0-fold (0.30 log units) below, within the range that was stated.
By their numbers in this assay, from the lowest: compounds 3 and 2 (each within the scatter of the next); then compounds 1 and 4 (each within the scatter of the next).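

In this assay, the position para to a large group on the six-membered aromatic ring of carbon only is shown for the first time to respond to a change, since all earlier compounds carried nitro: butyl in place of nitro gives a 3.9-fold higher number from compound 3 to compound 4 (0.59 log units; beyond the scatter). The change runs toward weaker inhibition, yet compound 4 still gives a number, 15900 nM, so a reading in this assay does not require nitro at this position. Nothing available bears on why the number rises, and the data do not separate the loss of nitro from the arrival of butyl.

From the compounds shown here alone, it remains open whether hydrogen, methyl, a longer chain, an amine or a carboxylic acid at this position would give a number closer to that of compound 3 or to that of compound 4. Also open, going by these compounds, is whether butyl in place of nitro would produce a step of similar size on the core of compound 1, which carries methyl, or whether the step holds only for the shared core of compound 3.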